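One group swapped between compound 3 and compound 4

The source may hold more compounds than are shown below. What is called first, only, known or untested is meant among the compounds shown, and "the series" means these compounds.

- Compound 1 `O=C(O)c1cc(=O)c2cccc(OCCCCCOc3ccccc3)c2o1`: 9 ug/mL
- Compound 2 `CC(=O)c1ccc(OCCCCCOc2ccc3c(=O)cc(C(=O)O)oc3c2)cc1`: 3.5 ug/mL
- Compound 3 `C=CCc1c(OCCCCCOc2cccc(O)c2C(C)=O)ccc2c(=O)cc(C(=O)O)oc12`: 0.05 ug/mL

These numbers come from a functional assay on ileum (Cavia porcellus) for antagonist activity, with a stated time of 30 s; on this read-out higher numbers stand for weaker inhibition and lower numbers for stronger inhibition. Compound 3 has the lowest number of the three, and its gaps to compound 1 and compound 2 lie beyond the usual scatter, so it is the strongest inhibitor here.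

Compound 4 `C=CCc1c(OCCCCCOc2ccc(C(C)=O)cc2)ccc2c(=O)cc(C(=O)O)oc12` has not been measured. It keeps the core of compound 3 and changes one group: a group of 9 heavy atoms (8 carbon, 1 oxygen; one six-membered aromatic ring of carbon only) in place of a group of 10 heavy atoms (8 carbon, 2 oxygen; one six-membered aromatic ring of carbon only), on an oxygen on a saturated carbon. Going by the values given here, no measured pair shows this change on its own, so any forecast is uncertain. The entering 4-acetylphenyl group also occurs in compound 2, which has a different core and gives 3.5 ug/mL, while compound 3 gives 0.05 ug/mL. On these two values, a rise in the number beyond the scatter is expected in this assay, meaning weaker inhibition, though probably not as far as the value of compound 2. The expected size is an 8.0-fold higher number from compound 3 to compound 4 (0.90 log units; beyond the scatter). Compound 4 is estimated at 0.4 ug/mL, with an expected range from 0.08 ug/mL to 2 ug/mL.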

Compound 4, half-maximal inhibitory concentration: 2.4 ug/mL
Estimate against measurement, compound 4: 6.0-fold (0.78 log units) below, outside the stated range (above it).
By their numbers in this assay, from the lowest: compound 3; then compounds 4 and 2 (each within the scatter of the next); then compound 1.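

Going by these compounds alone, on an oxygen on a saturated carbon, putting 4-acetylphenyl, with 0 hydrogen-bond donors, in place of the group of compound 3, with 1 hydrogen-bond donor, gives a 48-fold higher number from compound 3 to compound 4 (1.68 log units; beyond the scatter) in this assay, so the group at this place can shift the read-out strongly, which the earlier compounds could not show on their own. Allyl in place of hydrogen on an aromatic carbon gives a 1.5-fold lower number from compound 2 to compound 4 (0.16 log units; within the scatter), so with 4-acetylphenyl in place, this swap makes no difference that stands clear of the scatter. Nothing measured here explains the large step.

On these data alone, it stays open whether the hydrogen-bond donor or some other feature of the group in compound 3 accounts for that step, and whether allyl matters when that group is present. An amine on the same aromatic ring, or a longer chain leading to it, would test how narrow this requirement is.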